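Swapping an amide aryl group in a quinazoline-type series

The compounds below may be only part of what the source reports. "The series", "measured", "known", "first", "only" and "open" are said of these compounds alone.

Measured so far:
compound 1, `COc1cc2nc(SCC(=O)Nc3cccc(S(N)(=O)=O)c3)nc(Nc3c(Cl)cc(/C=C/C#N)cc3Cl)c2cc1OC`: > 194000 nM
compound 2, `COc1cc2nc([S+]([O-])CC(=O)Nc3cccc(C(F)(F)F)c3)nc(Nc3c(Cl)cc(/C=C/C#N)cc3Cl)c2cc1OC`: 21800 nM

Of the compounds shown here, two have been tested in an ADME assay on MT4 cells (Homo sapiens) for cytotoxicity, read by MTT assay, with a stated time of 5 days; a higher number here means that more compound is tolerated, a lower number that less compound is tolerated. For compound 1 the result is a limit of the assay rather than a number, > 194000 nM; the same is recorded as the limit of > 194000 nM in this assay, at which 1 of the 2 values shown sits. Compound 2 gives 21800 nM, the only number shown, so it alone fixes a point on this scale.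

Compound 3, `COc1ccccc1NC(=O)C[S+]([O-])c1nc(Nc2c(Cl)cc(/C=C/C#N)cc2Cl)c2cc(OC)c(OC)cc2n1`, has not yet been measured. It differs from compound 2 in one place: 2-methoxyphenyl in place of 3-(trifluoromethyl)phenyl on an amide-type nitrogen. Among the compounds with values here, no step between two measured compounds covers this change, so the size of the step is open. Compound 3 is expected to lie a little above compound 2, by about a 1.8-fold higher number from compound 2 to compound 3 (0.26 log units; within the scatter), though a result within the usual scatter would not surprise. For compound 3 the estimate is 40000 nM, with a range from 12000 nM to 150000 nM.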

Compound 3, half-maximal cytotoxic concentration: > 204000 nM
Compound 3: no number, only a limit; the forecaster's own chance of this, stated with the estimate: 25%; at least 5.1-fold (0.70 log units) between middle value and limit.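

In this assay, 2-methoxyphenyl in place of 3-(trifluoromethyl)phenyl on the amide-type nitrogen gives an at least 9.3-fold higher number from compound 2 to compound 3 (0.97 log units; beyond the scatter). Within the data shown here, this is the first comparison here between compounds that differ in one place, and it shows that a change in this aryl group alone can move the result beyond the usual scatter. Compound 3 gives no number, only a limit of the assay, so the full size of the step stays unknown: the limit of > 204000 nM in this assay, at which 1 of the 3 values shown sits.

Among these compounds, the single pair changes both the group and the ring position at which it sits, so it does not separate the gain from either one. From the compounds shown here alone, how a plain phenyl, a 3-methoxyphenyl or a 2-(trifluoromethyl)phenyl would behave on this nitrogen remains open.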